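The source may report more compounds than this note shows. Statements on the series, on what has been measured and on what is new or still open speak of the compounds shown alone.

Values in a functional assay on HeLa cells (Homo sapiens) for antiproliferative activity, read by MTT assay, with a stated time of 72 h; a higher number here means a weaker inhibitor, a lower number a stronger inhibitor:
compound 1 (`COc1cccc(N2C(=O)COc3ccc(-c4ccc(O)cc4)cc32)c1`) gives > 40000 nM (a limit of the assay, not a number)
compound 2 (`O=C1COc2ccc(-c3cccc(NS(=O)(=O)c4ccc(F)cc4)c3)cc2N1c1ccc(Cl)cc1`) gives 35000 nM (a measured number)

Among the compounds with values here, the only number so far belongs to compound 2. The value of compound 1 is a limit.

Compound 3 (`O=C1COc2ccc(-c3cccc(NS(=O)(=O)c4ccc(F)cc4)c3)cc2N1c1ccc(F)cc1`) keeps all of compound 2 except one substituent: fluoro in place of chloro on an aromatic carbon. In words, this is fluoro in place of chloro on an aromatic carbon, para to a large group, so that 4-chlorophenyl becomes 4-fluorophenyl.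

Within the data shown here, no measured pair shows this exchange, so the data give no size for it. With compound 2 at 35000 nM as the only anchor, no change beyond the usual scatter is expected in this assay and no direction is favoured. The expected step of no change at the digits printed from compound 2 to compound 3 (within the scatter) stays within that scatter. A report of only a limit for compound 3 would also be no surprise. For compound 3 the estimated value is 35000 nM and the expected range runs from 15000 nM to 60000 nM in this series.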

Compound 3, half-maximal inhibitory concentration: > 40000 nM
Compound 3: no number, only a limit (the forecaster's own chance of this, stated with the estimate: 35%); middle value at least 1.1-fold (0.05 log units) from the limit.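

In this assay compound 3 gives > 40000 nM, which is a limit of the assay and not a number. Within the data shown here, this is the first pair that differs in one place, and the exchange of 4-chlorophenyl for 4-fluorophenyl reads as an at least 1.1-fold higher number from compound 2 to compound 3 (0.05 log units; that floor lies within the scatter), so on the aromatic carbon para to a large group the data fix only a floor for the step, with no upper end. The floor gives no evidence that this halogen exchange changes the read-out, and the series leaves little room to read a step of this kind: the limit of > 40000 nM in this assay, at which 2 of the 3 values shown sit.

Going by these compounds, the true size of the step stays open, as does the question of whether any exchange at this place can move a value beyond the scatter. Among these compounds, also open is how an amine or a carboxylic acid in the place of the halogen on this ring would read in this assay, where compound 2 at 35000 nM remains the only number.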